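The source may hold more compounds than are shown below. What is called first, only, known or untested is meant among the compounds shown, and "the series" means these compounds.

Measured so far in an assay on isolated protein for binding affinity to stress-70 protein, mitochondrial (Homo sapiens); on this read-out lower numbers stand for tighter binding and higher numbers for weaker binding:
compound 1 `CN1c2ccc(NC(=O)Nc3ccc(OC(F)(F)F)cc3)cc2C(C)(C)C(=O)C1(C)C`: 1800 nM
compound 2 `CN1c2ccc(NC(=O)Nc3ccc([N+](=O)[O-])cc3)cc2C(C)(C)C(O)C1(C)C`: 1600 nM
compound 3 `CN1c2ccc(NC(=O)Nc3ccc(C(F)(F)F)cc3)cc2C(C)(C)C(O)C1(C)C`: 700 nM

Compound 3 gives the lowest of the three numbers. Among the measured compounds shown here, compound 2 stands higher, a 2.3-fold lower number from compound 2 to compound 3 (0.36 log units; beyond the scatter), and compound 1 stands higher still, though compound 1 differs from compound 3 in two places, so no single step connects them.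

Compound 4 `CN1c2ccc(NC(=O)Nc3ccc(OC(F)(F)F)cc3)cc2C(C)(C)C(O)C1(C)C` is not yet measured. It differs from compound 3 in one place: trifluoromethoxy in place of trifluoromethyl on an aromatic carbon. For the measured compounds named here, the only measured step at the same aromatic carbon is a 2.3-fold lower number from compound 2 to compound 3 (0.36 log units; beyond the scatter), a modest shift for one exchange of the group there. Going by the values given here, no measured pair isolates the exchange of trifluoromethyl for trifluoromethoxy. Compound 1 carries trifluoromethoxy on that ring and gives 1800 nM, but it also carries a carbonyl where compound 4 carries a hydroxyl, so its number is only a loose reference. On that basis the step expected in this assay is small and probably toward a somewhat higher number: a 1.7-fold higher number from compound 3 to compound 4 (0.23 log units; within the scatter). For compound 4 in this assay the expected value is 1200 nM, with a range from 500 nM to 3000 nM.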

Compound 4, dissociation constant: 1100 nM
The estimate for compound 4 lay 1.1-fold (0.04 log units) above the measured number; the measured number falls inside the stated range.
By their numbers in this assay, from the lowest: compounds 3, 4, 2 and 1 (each within the scatter of the next, the first and the last beyond it).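

In this assay, the aromatic carbon para to a large group can now be read across three groups on the same hydroxyl-bearing core, with trifluoromethoxy compared directly against both trifluoromethyl (a 1.6-fold higher number from compound 3 to compound 4 (0.20 log units; within the scatter)) and nitro (a 1.5-fold lower number from compound 2 to compound 4 (0.16 log units; within the scatter)). Among the compounds shown here, both new steps lie within the scatter, so compound 4 cannot be separated from either neighbour, and the only step at this position beyond the scatter remains the modest one (a 2.3-fold lower number from compound 2 to compound 3 (0.36 log units; beyond the scatter)). For the compounds shown here, the numbers alone offer no account of these steps, and no accompanying measurement bears on them.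

Still open, from the compounds shown here alone, is whether this position tolerates groups of a different kind as readily, such as an amine, a carboxylic acid or a longer alkyl chain, since the three groups compared here span only a narrow set of steps. Going by these compounds alone, also open is how far the exchange of hydroxyl for carbonyl matters, as only one pair speaks to it, with compound 4 at 1100 nM and compound 1 at 1800 nM, both carrying trifluoromethoxy.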